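Fluorinated ring swap at the limit of a cell test

The source may report more compounds than this note shows. Statements on the series, on what has been measured and on what is new or still open speak of the compounds shown alone.

Compound 1 `O=[N+]([O-])c1cn2c(n1)OC(COc1cccc(-c3ccc(F)nc3F)n1)CC2`: > 64000 nM
Compound 2 `CC1(COc2cccc(-c3ccc(F)cc3F)n2)CCn2cc([N+](=O)[O-])nc2O1`: > 64000 nM

Both entries come from an ADME assay on MRC5 cells (Homo sapiens) for cytotoxicity, read by resazurin assay, with a stated time of 72 h (on this read-out higher numbers stand for weaker inhibition and lower numbers for stronger inhibition), and neither is a true number. Compound 2 stands at the limit of > 64000 nM in this assay, at which 2 of the 2 values shown sit. Compound 3 `CC1(COc2cccc(-c3ccc(F)nc3F)n2)CCn2cc([N+](=O)[O-])nc2O1` differs from compound 2 by one swap: 2,6-difluoropyridin-3-yl in place of 2,4-difluorophenyl on an aromatic carbon. It puts 2,6-difluoropyridin-3-yl in place of 2,4-difluorophenyl. Compound 1 already carries 2,6-difluoropyridin-3-yl, and its entry is also a limit, > 64000 nM. No step beyond the scatter is therefore expected in this assay, in either direction. The estimated change is a number no higher from compound 2 to compound 3 (the limit leaves the size open). The expected value for compound 3 is 64000 nM, with an estimated range from 30000 nM to 128000 nM.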

Compound 3, half-maximal inhibitory concentration: > 64000 nM
Compound 3: only a limit was reported (the forecaster's own chance of this, stated with the estimate: 85%); the middle value lies on the limit itself.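

In this assay, among these compounds, compound 3 also gives only a limit, so no step from compound 1 or compound 2 to compound 3 can be read. The compounds shown leave open what true numbers lie behind these limits, and so whether either structural change alters the read-out.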